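A few compounds are considered here, and "the series" means these few. Any claim that something is new, unique, unknown or untested is made for them only; others in the source may bear on it.

Measured so far:
- compound 1 `CO[C@H]1CC[C@H](N2CC(=O)Nc3ncc(-c4ccc(C(C)(C)O)nc4)nc32)CC1`: in an ADME assay on S9 fraction (Rattus norvegicus) for metabolic stability, with a stated time of 60 min (a higher number here means that more of the compound is left, a lower number that less of the compound is left), compound 1 gives 94%
- compound 2 `COCCN1C(=O)CNc2ncc(-c3ccc(C(C)(C)O)nc3)nc21`: in this assay compound 2 gives 89%
- compound 3 `O=c1[nH]c2ncc(-c3ccc(-c4nc[nH]n4)cc3)nc2n1CCC1CCOCC1`: in this assay compound 3 gives 93%

All three numbers sit high and close together. Compound 2 has the lowest of the three, but its gap to compound 3 and its gap to compound 1 both fall inside the usual scatter, so no order among the three can be read from these figures.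

The step under consideration goes from compound 2 to compound 4 `CO[C@H]1CC[C@H](N2C(=O)CNc3ncc(-c4ccc(C(C)(C)O)nc4)nc32)CC1`, which is not yet measured in this assay. The change is 4-methoxycyclohexyl in place of 2-methoxyethyl on an amide-type nitrogen in a ring. For the measured compounds named here, no measured pair shows this exact change. Compound 1, which also bears a 4-methoxycyclohexyl group on its core, gives 94% in this assay, and compound 2 gives 89%, two values that lie within the scatter of each other.

On that basis the step from compound 2 to compound 4 is expected to be none beyond the scatter, estimated as a number 2 percentage points higher from compound 2 to compound 4 (within the scatter). For compound 4 the expected value in this assay is 91%, with a likely range from 80% to 98%.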

Compound 4, percent of the compound remaining: 81%
For compound 4 the middle estimate is 10 percentage points above the measured one, and the stated range covers the measured number.
By their numbers in this assay, from the lowest: compounds 4, 2, 3 and 1 (each within the scatter of the next, the first and the last beyond it).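

In this assay, for the compounds shown here, this is the first direct reading of 4-methoxycyclohexyl in place of 2-methoxyethyl on the amide-type nitrogen in a ring, and it gives a number 8 percentage points lower from compound 2 to compound 4 (within the scatter). The position therefore carries a six-membered carbon ring with 2 defined stereocentres, and 8 heavy atoms against the 4 of the chain it replaces, without a step beyond the scatter, and compound 4 still stands at 81% after the stated time. Nothing available bears on why the number falls where it does.

This rests on a single pair, so it sets no trend for the position, and the size of the step says nothing about whether the same exchange would behave alike on a different core. Going by these compounds alone, it remains open whether a 4-hydroxycyclohexyl group, a longer ether chain or a chain ending in an amine on this nitrogen would also stay within the scatter of compound 2, or would give the first step beyond it.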